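Swapping Cyclopropyl for Phenyl on the Amide Nitrogen

A few compounds are considered here, and "the series" means these few. Any claim that something is new, unique, unknown or untested is made for them only; others in the source may bear on it.

The measured compounds and their values:
- compound 1, `COc1ncc(-c2ccc3c(c2)N(c2ccc(C)cc2)C(=O)CO3)cc1NS(=O)(=O)c1ccc(F)cc1`: 22700 nM
- compound 2, `O=C1COc2ccc(-c3cccc(NS(=O)(=O)c4ccc(F)cc4)c3)cc2N1C1CC1`: > 40000 nM
- compound 3, `COc1ccc(N2C(=O)COc3ccc(-c4cnc5ccccc5c4)cc32)cc1`: > 40000 nM

All three were tested in a functional assay on HCT-116 cells (Homo sapiens) for antiproliferative activity, read by MTT assay, with a stated time of 72 h; a higher number here means a weaker inhibitor, a lower number a stronger inhibitor. Compound 1 gives 22700 nM, a weak but measurable result. For compound 2 the value > 40000 nM is a limit of the assay rather than a number. For compound 3 the value > 40000 nM is likewise only a limit. Compound 2 therefore stands at the weak end of what is shown, together with compound 3, and there is no measured step to build on: the limit of > 40000 nM in this assay, at which 2 of the 3 values shown sit.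

Compound 4, `O=C1COc2ccc(-c3cccc(NS(=O)(=O)c4ccc(F)cc4)c3)cc2N1c1ccccc1`, has not yet been measured. It differs from compound 2 in one place: phenyl in place of cyclopropyl on an amide-type nitrogen in a ring. Compound 1, which also carries an aromatic ring on its amide-type nitrogen in a ring, gives 22700 nM, although it differs from compound 4 in other places as well, so that value only hints at what an aromatic ring there allows.

With compound 2 at a limit, any step can only be guessed. The expectation is that the step from compound 2 to compound 4 in this assay, an at least 1.3-fold lower number from compound 2 to compound 4 (0.12 log units; that floor lies within the scatter), is small or none beyond the usual scatter, perhaps bringing compound 4 just into the measurable range. Compound 4 is estimated at 30000 nM, with a range from 10000 nM to 60000 nM.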

Compound 4, half-maximal inhibitory concentration: > 40000 nM
Compound 4: a limit, no number; the forecaster's own chance of this, stated with the estimate: 50%; middle value at least 1.3-fold (0.12 log units) from the limit.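

Compound 4 gives > 40000 nM in this assay and that value is a limit, not a number. Among these compounds, compound 2 also stands at a limit, and no step between compound 2 and compound 4 can be read, because both sit at the same end of the scale: the limit of > 40000 nM in this assay, at which 3 of the 4 values shown sit. Going by these compounds, whether phenyl in place of cyclopropyl on the amide-type nitrogen changes activity at all stays open.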